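The source may report more compounds than this note shows. Statements on the series, on what has been measured and on what is new or still open speak of the compounds shown alone.

Working notes on a short ester series built on one shared core, all compared in a functional assay on MDA-MB-231 cells (Homo sapiens) for antiproliferative activity, read by MTT assay, with a stated time of 72 h; a higher number here means a weaker inhibitor, a lower number a stronger inhibitor. Compound 1 `CC1=CC[C@H]2[C@H](CC[C@]2(C)O)C(C)(C)[C@@H]1CC[C@H]1[C@]2(C)CC[C@H](OC(=O)c3ccc([N+](=O)[O-])cc3)C(C)(C)O[C@H]2CC[C@@]1(C)O` gives 8900 nM in this assay. Compound 2 `CC1=CC[C@H]2[C@H](CC[C@]2(C)O)C(C)(C)[C@@H]1CC[C@H]1[C@]2(C)CC[C@H](OC(=O)c3ccc(C(F)(F)F)cc3)C(C)(C)O[C@H]2CC[C@@]1(C)O` gives 19500 nM. Compound 3 `CC1=CC[C@H]2[C@H](CC[C@]2(C)O)C(C)(C)[C@@H]1CC[C@H]1[C@]2(C)CC[C@H](OC(=O)c3cccc([N+](=O)[O-])c3)C(C)(C)O[C@H]2CC[C@@]1(C)O` gives 34700 nM. Compound 4 `CC1=CC[C@H]2[C@H](CC[C@]2(C)O)C(C)(C)[C@@H]1CC[C@H]1[C@]2(C)CC[C@H](OC(=O)c3cccc(C(F)(F)F)c3)C(C)(C)O[C@H]2CC[C@@]1(C)O` has not yet been measured in this assay.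

The change from compound 1 to compound 2 is trifluoromethyl in place of nitro on an aromatic carbon; it made a 2.2-fold higher number from compound 1 to compound 2 (0.34 log units; beyond the scatter). The cores of compound 1 and compound 3 differ as 3-nitrophenyl in place of 4-nitrophenyl on a carbonyl carbon, with a 3.9-fold higher number from compound 1 to compound 3 (0.59 log units; beyond the scatter). Between compound 2 and compound 3 the step is a 1.8-fold higher number from compound 2 to compound 3 (0.25 log units; within the scatter). Compound 3 carries the highest number of the three measured, and only its step from compound 1 is beyond the scatter.

The change from compound 3 to compound 4 is trifluoromethyl in place of nitro on an aromatic carbon. The leaving and entering groups match those of the change from compound 1 to compound 2, and the change occurs twice in all among the compounds shown, but the place differs: in the earlier pair the aromatic carbon is "para to a large group", here it is "meta to a large group". It is therefore the same kind of change, not the same change. Going by the values given here, only one measured example exists, so the expectation rests on that single step and on the value of compound 3. Among the compounds with values here, from compound 3 to compound 4 a step of about a 2.0-fold higher number from compound 3 to compound 4 (0.30 log units; within the scatter) is expected, guided by a 2.2-fold higher number from compound 1 to compound 2 (0.34 log units; beyond the scatter) as the sole precedent. Compound 4 is accordingly estimated at 70000 nM in this assay. The expected range for compound 4 runs from 30000 nM to 160000 nM, kept wide since the place of the change differs from the measured example. Compound 3 already stands at 34700 nM, so compound 4 is expected to fall outside the span covered by the three measured compounds.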

Compound 4, half-maximal inhibitory concentration: 36300 nM
Compound 4: middle estimate off by 1.9-fold (0.29 log units), on the high side; the range from low to high includes it.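

In this assay, trifluoromethyl in place of nitro on the 3-nitrophenyl ester gives a 1.0-fold higher number from compound 3 to compound 4 (0.02 log units; within the scatter), and this step does not differ from the earlier example of the same change on the 4-nitrophenyl ester: the same change on two cores in this assay, a 2.2-fold higher number (0.34 log units; beyond the scatter) from compound 1 to compound 2 and a 1.0-fold higher number (0.02 log units; within the scatter) from compound 3 to compound 4, 2.1-fold (0.32 log units) apart, within the scatter of two such steps.

Going by these compounds alone, this fits the change carrying over between the two esters, but it does not establish a constant step, as there are only two pairs, and it cannot show whether the place on the ring alters the outcome. The other new steps are a 1.9-fold higher number from compound 2 to compound 4 (0.27 log units; within the scatter), which stays within the scatter for 3-(trifluoromethyl)phenyl in place of 4-(trifluoromethyl)phenyl, and a 4.1-fold higher number from compound 1 to compound 4 (0.61 log units; beyond the scatter), which lies beyond it, leaving compound 1 as the strongest of the four compounds in this assay.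

The compounds shown leave open whether a nitrile, an amine or a carboxylic acid on the same aromatic ring would stay close to compound 1 or to the other three compounds. Also open, from the compounds shown here alone, is whether the step from nitro to trifluoromethyl would hold with an amide in place of the ester link, or on a core changed elsewhere.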